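The source may hold more compounds than are shown below. What is called first, only, known or untested is meant among the compounds shown, and "the series" means these compounds.

In a functional assay on A-375 cells (Homo sapiens) for cytotoxicity, read by MTT assay, with a stated time of 72 h (a higher number here means a weaker inhibitor, a lower number a stronger inhibitor), compound 1 `O=C1c2c[n+]([O-])c3ccccc3c2C(=O)c2c1c1ccccc1n2Cc1cn(CC(O)CO)nn1` gives 440 nM, and compound 2 `CC1(C)OC[C@H](Cn2cc(Cn3c4c(c5ccccc53)C(=O)c3c[n+]([O-])c5ccccc5c3C4=O)nn2)O1` gives 180 nM. Compound 1 therefore stands at the higher of the two numbers, the weaker of the pair. Compound 3 `O=C1c2c[n+]([O-])c3ccccc3c2C(=O)c2c1c1ccccc1n2CCCCN1CCCCC1` keeps the core of compound 1 and differs only in its side chain: 3-(piperidin-1-yl)propyl in place of 1-(2,3-dihydroxypropyl)-1H-1,2,3-triazol-4-yl on a saturated chain carbon bound to an aromatic nitrogen. Here 3-(piperidin-1-yl)propyl takes the place of 1-(2,3-dihydroxypropyl)-1H-1,2,3-triazol-4-yl, on a saturated chain carbon bound to an aromatic nitrogen.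

Within the data shown here, only one measured step bears on this change, and only in part: a 2.4-fold lower number from compound 1 to compound 2 (0.39 log units; beyond the scatter), which is modest and beyond the scatter. On these data alone, in that step 2,2-dimethyl-1,3-dioxolan-4-yl replaces 1,2-dihydroxyethyl while the triazole stays, so the exchange of the whole group remains untested. Among the measured compounds shown here, the data hold no compound with a piperidin-1-yl group. For the measured compounds named here, on the single precedent of a 2.4-fold lower number from compound 1 to compound 2 (0.39 log units; beyond the scatter), a step of similar or somewhat larger size toward a lower number seems the best guess, held with little confidence. The expected step is a 2.9-fold lower number from compound 1 to compound 3 (0.47 log units; beyond the scatter). For compound 3 the estimated value is 150 nM, with an expected range of 40 nM to 600 nM.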

Compound 3, half-maximal inhibitory concentration: 190 nM
Compound 3: the middle estimate sits 1.3-fold (0.10 log units) below what was measured; the range from low to high includes it.
By their numbers in this assay, from the lowest: compounds 2 and 3 (each within the scatter of the next); then compound 1.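

Replacing the whole side chain gives a 2.3-fold lower number from compound 1 to compound 3 (0.36 log units; beyond the scatter) in this assay, so the number at this place, a saturated chain carbon bound to an aromatic nitrogen, does not depend on keeping the triazole or the two hydroxyl groups. The earlier pair had changed only the diol end of the side chain while the triazole stayed, whereas 3-(piperidin-1-yl)propyl has no five-membered aromatic ring and no hydrogen-bond donors, and compound 3 still lies on the lower side of compound 1. Nothing in the data explains why this exchange lowers the number.

The compounds shown leave open which part of the new group carries the step, since the triazole, the diol and the chain all change together between compound 1 and compound 3. A morpholin-4-yl or dimethylamino group at the end of the same chain, or a piperidin-1-yl group carried on the triazole itself, would help to separate these contributions.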